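Compound 3 to compound 4: methoxy to hydroxy

The source may report more compounds than this note shows. Statements on the series, on what has been measured and on what is new or still open speak of the compounds shown alone.

compound 1 `COc1ccc(/C=C2\CCC/C(=C\c3ccc(Br)cc3)C2=O)cc1OC` gives 5200 nM
compound 2 `COc1ccc(/C=C2\CCC/C(=C\c3ccc(O)cc3)C2=O)cc1OC` gives 7700 nM
compound 3 `COc1ccc(/C=C2\CCC/C(=C\c3ccc(OC)c(OC)c3)C2=O)cc1OC` gives 4500 nM

In a functional assay on SW-620 cells (Homo sapiens) for cytotoxicity, read by MTT assay, with a stated time of 72 h (on this read-out lower numbers stand for stronger inhibition and higher numbers for weaker inhibition), compound 3 at 4500 nM sits within the scatter of both other values and stands apart from neither compound 1 nor compound 2. The change to compound 4 `COc1cc(/C=C2\CCC/C(=C\c3ccc(OC)c(OC)c3)C2=O)ccc1O` is hydrogen in place of methyl on an oxygen on an aromatic ring and amounts to hydrogen in place of methyl on an oxygen on an aromatic ring, methoxy to hydroxy. For the measured compounds named here, no measured step makes this exact change. The closest is a 1.5-fold higher number from compound 1 to compound 2 (0.17 log units; within the scatter) for hydroxy in place of bromo on an aromatic carbon. No step beyond the scatter is therefore expected in this assay in either direction. The expected change is a 1.2-fold higher number from compound 3 to compound 4 (0.09 log units; within the scatter) and no more. For compound 4 the estimated value is 5500 nM with an expected range of 2800 nM to 11000 nM in this series.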

Compound 4, half-maximal inhibitory concentration: 4500 nM
For compound 4 the middle estimate is 1.2-fold (0.09 log units) above the measured one; the range from low to high includes it.
By their numbers in this assay, from the lowest: compounds 3, 4, 1 and 2 (each within the scatter of the next).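

In this assay, for the compounds shown here, hydrogen in place of methyl on the oxygen on the aromatic ring gives no change at the digits printed from compound 3 to compound 4 (within the scatter) as the first direct reading of this change, so methoxy and hydroxy at this place cannot be told apart here. The wider comparisons also stay inside the scatter, with a 1.7-fold lower number from compound 2 to compound 4 (0.23 log units; within the scatter) and a 1.2-fold lower number from compound 1 to compound 4 (0.06 log units; within the scatter), so this change separates none of the four compounds. No supporting data bear on this result.

Still open, going by these compounds, is whether an amine or a carboxylic acid on this aromatic ring would give a step beyond the scatter.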